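Tert-butoxycarbonyl in place of phenyl on the ring nitrogen

The source may report more compounds than this note shows. Statements on the series, on what has been measured and on what is new or still open speak of the compounds shown alone.

Values so far in a functional assay on U-937 cells (Homo sapiens) for cytotoxicity, read by MTT assay, with a stated time of 24 h; on this read-out higher numbers stand for weaker inhibition and lower numbers for stronger inhibition
compound 1 (`CN1CCN(CCCCCOc2c(Br)cc(Br)cc2Oc2ccc(Br)cc2Br)CC1`): 49.1 ug/mL
compound 2 (`Brc1ccc(Oc2cc(Br)cc(Br)c2OCCCCCN2CCN(c3ccccc3)CC2)c(Br)c1`): 42.5 ug/mL
compound 3 (`CC(=O)Oc1c(Br)cc(Br)cc1Oc1ccc(Br)cc1Br`): 32.3 ug/mL

Compound 2 at 42.5 ug/mL lies within the usual scatter of both compound 1 and compound 3, so these numbers give no ranking around it. Compound 3, which has no such nitrogen ring, shows 32.3 ug/mL in the same range. Compound 4 (`CC(C)(C)OC(=O)N1CCN(CCCCCOc2c(Br)cc(Br)cc2Oc2ccc(Br)cc2Br)CC1`) has yet to be measured in this assay and carries tert-butoxycarbonyl in place of phenyl on an amine nitrogen in a ring. For the measured compounds named here, one measured step bears on this nitrogen: phenyl in place of methyl (a 1.2-fold lower number from compound 1 to compound 2 (0.06 log units; within the scatter)), which is small and within the scatter. Going by the values given here, that is a single step, and no compound with a carbonyl on this nitrogen has been measured, so the basis is thin and the range stays wide. No step beyond the scatter is expected, in either direction. The estimated change is small (a 1.1-fold lower number from compound 2 to compound 4 (0.03 log units; within the scatter)) and is expected to stay within the scatter. Compound 4 is expected at 40 ug/mL (estimated range 24 ug/mL to 66 ug/mL).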

Compound 4, half-maximal inhibitory concentration: 35.5 ug/mL
Compound 4: middle estimate off by 1.1-fold (0.05 log units), on the high side, within the range that was stated.
By their numbers in this assay, from the lowest: compounds 3, 4, 2 and 1 (each within the scatter of the next).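

In this assay, the ring nitrogen now carries a group of a different kind: tert-butoxycarbonyl has no ring and brings a carbonyl and 2 hydrogen-bond acceptors, where phenyl has a six-membered aromatic ring and 0 acceptors, and the exchange gives a 1.2-fold lower number from compound 2 to compound 4 (0.08 log units; within the scatter). Measured against the small methyl group, the same group gives a 1.4-fold lower number from compound 1 to compound 4 (0.14 log units; within the scatter), so this wider comparison also stays inside the scatter, and methyl, phenyl and tert-butoxycarbonyl on this nitrogen are not told apart by this read-out, even with that spread in ring content and acceptor count. Nothing at hand speaks to why the three compounds fall so close together.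

The compounds shown leave open whether any group on this nitrogen can move the number beyond the scatter, for example a free amine hydrogen, a carboxylic acid on a short chain or a benzyl group. Also open, as far as these compounds go, is whether the five-carbon chain of the core of compound 1 matters in this assay, which a shorter or a longer chain with the same ring nitrogen group would show.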